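From compound 3 back towards a simple amide

The compounds below may be only part of what the source reports. "The series", "measured", "known", "first", "only" and "open" are said of these compounds alone.

In a functional assay on the whole organism with Mus musculus as the target, in the rotarod test (on this read-out lower numbers stand for an effect already at smaller amounts and higher numbers for an effect only at larger amounts of compound), compound 3 `CC(NC(=O)CN)C(=O)N(C)c1ccc(Cl)cc1C(=O)c1ccccc1Cl` gives 8.5 mg/kg. Compound 1 `CC(C)NCC(=O)NCC(=O)N(C)c1ccc(Cl)cc1C(=O)c1ccccc1Cl` gives 13 mg/kg, and a 1.5-fold lower number from compound 1 to compound 3 (0.18 log units; within the scatter), so these two cannot be told apart. Compound 2 `CC(=O)NCC(=O)N(C)c1ccc(Cl)cc1C(=O)c1ccccc1Cl` stands apart at 58 mg/kg.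

Compound 4 `CCC(=O)NCC(=O)N(C)c1ccc(Cl)cc1C(=O)c1ccccc1Cl` has (propanoylamino)methyl in place of 1-(((aminomethyl)carbonyl)amino)ethyl on a carbonyl carbon. Compound 2 carries acetamidomethyl, the measured group closest to the one entering, so the most relevant step is a 6.8-fold lower number from compound 2 to compound 3 (0.83 log units; beyond the scatter), read in reverse. Also relevant is a 4.5-fold higher number from compound 1 to compound 2 (0.65 log units; beyond the scatter), which points the same way. On that basis, the estimated change is a 5.9-fold higher number from compound 3 to compound 4 (0.77 log units; beyond the scatter), a clear move to a higher number in this assay. Compound 4 is expected at 50 mg/kg, within an estimated range of 22 mg/kg to 110 mg/kg.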

Compound 4, dose for half-maximal effect: 36 mg/kg
Compound 4: the middle estimate sits 1.4-fold (0.14 log units) above what was measured; the measured number falls inside the stated range.
By their numbers in this assay, from the lowest: compounds 3 and 1 (each within the scatter of the next); then compounds 4 and 2 (each within the scatter of the next).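

Adding one methyl to the simple amide chain does not separate the two amides in this assay: a 1.6-fold lower number from compound 2 to compound 4 (0.21 log units; within the scatter). Putting that same methyl in place of isopropylamino gives a 2.8-fold higher number from compound 1 to compound 4 (0.44 log units; beyond the scatter), and the swap to (propanoylamino)methyl gives a 4.2-fold higher number from compound 3 to compound 4 (0.63 log units; beyond the scatter), so both compounds carrying an amine sit at lower numbers than both without one. Nothing measured here explains this difference.

On these data alone, whether a carboxylic acid or a longer butanoylamino chain in place of (propanoylamino)methyl would group with compound 1 and compound 3, or with compound 2 and compound 4, stays open.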